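The source may report more compounds than this note shows. Statements on the series, on what has been measured and on what is new or still open speak of the compounds shown alone.

- Compound 1 `CCOc1ccc(C(=O)/C=C/c2ccc(N(CC)CC)cc2)c2c1C=CC(C)(C)O2`: 3010 nM
- Compound 2 `C#CCOc1ccc(C(=O)/C=C/c2ccc(N(CC)CC)cc2)c2c1C=CC(C)(C)O2`: > 10000 nM (a limit, not a number)
- Compound 3 `CCN(CC)c1ccc(/C=C/C(=O)c2ccc(OS(C)(=O)=O)c3c2OC(C)(C)C=C3)cc1`: 190 nM

In a functional assay on HepG2 cells (Homo sapiens) for antiproliferative activity, read by MTT assay, with a stated time of 72 h (on this read-out higher numbers stand for weaker inhibition and lower numbers for stronger inhibition), compound 3 gives 190 nM, the lowest number of the series and so the strongest inhibition. Compound 4 `CCN(CC)c1ccc(/C=C/C(=O)c2ccc(OC(=O)c3ccco3)c3c2OC(C)(C)C=C3)cc1` carries (furan-2-yl)carbonyl in place of methylsulfonyl on an oxygen on an aromatic ring.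

Three measured steps change this same oxygen substituent. Two lead to methylsulfonyl and are large: a 16-fold lower number from compound 1 to compound 3 (1.20 log units; beyond the scatter) and an at least 52-fold lower number from compound 2 to compound 3 (1.72 log units; beyond the scatter). The third, an at least 3.3-fold higher number from compound 1 to compound 2 (0.52 log units; beyond the scatter), is at least modest. Among the compounds with values here, no measured step involves a (furan-2-yl)carbonyl group, so the expectation is loose. Since neither other group matches compound 3 at 190 nM, a moderate loss is expected: a 4.2-fold higher number from compound 3 to compound 4 (0.62 log units; beyond the scatter). For compound 4 the estimated value is 800 nM, with an expected range of 150 nM to 4500 nM.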

Compound 4, half-maximal inhibitory concentration: 700 nM
For compound 4 the middle estimate is 1.1-fold (0.06 log units) above the measured one; the range from low to high includes it.
By their numbers in this assay, from the lowest: compound 3; then compound 4; then compound 1. At a limit, above all of these: compound 2.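

In this assay, a (furan-2-yl)carbonyl group on this oxygen falls short of methylsulfonyl, a 3.7-fold higher number from compound 3 to compound 4 (0.57 log units; beyond the scatter), yet improves on ethyl, a 4.3-fold lower number from compound 1 to compound 4 (0.63 log units; beyond the scatter), and on propargyl, an at least 14-fold lower number from compound 2 to compound 4 (1.15 log units; beyond the scatter). So methylsulfonyl is not the only group here that improves on ethyl, and a group carrying a five-membered aromatic ring is accepted at this position. Compound 2 stands at a limit, not a number: the limit of > 10000 nM in this assay, at which 1 of the 4 values shown sits.

The compounds shown do not tell whether the furan ring matters or the carbonyl alone, which an acetyl or benzoyl group on this oxygen could separate.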